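Weak cytotoxic diketopiperazine analogs: swapping one aryl substituent

The source may hold more compounds than are shown below. What is called first, only, known or untested is meant among the compounds shown, and "the series" means these compounds.

Three close analogs share one core and differ only in one aryl group. In a functional assay on NCI-H1975 cells (Homo sapiens) for cytotoxicity, read by CCK-8 assay, with a stated time of 72 h (a lower number here means a stronger inhibitor, a higher number a weaker inhibitor), compound 3 `C=CCn1c(=O)/c(=C\c2ccccc2C(F)(F)F)[nH]c(=O)/c1=C\c1ccccc1OC` gives 14500 nM, the lowest of the two numbers available. Compound 1 `C=CCn1c(=O)/c(=C\c2ccccc2OC)[nH]c(=O)/c1=C\c1ccccc1OC` gives 21500 nM, and the move a 1.5-fold lower number from compound 1 to compound 3 (0.17 log units; within the scatter) stays within the scatter. Compound 2 `C=CCn1c(=O)/c(=C\c2cccc(Br)c2)[nH]c(=O)/c1=C\c1ccccc1OC` is reported as "not active" (no number reported) without a number. Compound 4 `C=CCn1c(=O)/c(=C\c2cccc(C)c2)[nH]c(=O)/c1=C\c1ccccc1OC` is not yet measured; it differs from compound 3 by 3-methylphenyl in place of 2-(trifluoromethyl)phenyl on a double-bonded chain carbon bound to an aromatic carbon. For the measured compounds named here, only the step from compound 1 to compound 3 bears on this change, and it was small; compound 2, which also carries a different aryl group, gave no measurable number. The expected outcome for compound 4 is therefore a weak value near 25000 nM, ranging from 10000 nM to 80000 nM, which is the estimated step of a 1.7-fold higher number from compound 3 to compound 4 (0.24 log units; within the scatter) in this assay.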

Compound 4, half-maximal inhibitory concentration: 32800 nM
For compound 4 the middle estimate is 1.3-fold (0.12 log units) below the measured one, within the range that was stated.
By their numbers in this assay, from the lowest: compounds 3, 1 and 4 (each within the scatter of the next, the first and the last beyond it).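

In this assay, for the compounds shown here, 3-methylphenyl in place of 2-(trifluoromethyl)phenyl gives a 2.3-fold higher number from compound 3 to compound 4 (0.35 log units; beyond the scatter), the first step beyond the scatter, although it is modest. Replacing 2-methoxyphenyl with 3-methylphenyl gives a 1.5-fold higher number from compound 1 to compound 4 (0.18 log units; within the scatter), so only the two ends of this short series stand apart. No measured evidence accounts for either step. The aryl groups shown carry only methoxy, bromine, trifluoromethyl or methyl, so the effect of an amine or a carboxylic acid on that ring remains open. As far as these compounds go, whether any change at this position gives a strong inhibitor also remains open.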